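The source may hold more compounds than are shown below. What is called first, only, known or untested is meant among the compounds shown, and "the series" means these compounds.

Measured compounds in an ADME assay on HeLa cells (Homo sapiens) for cytotoxicity, read by MTT assay, with a stated time of 24 h; on this read-out lower numbers stand for stronger inhibition and higher numbers for weaker inhibition:
compound 1, `CSC(=S)N1CCN(C(=S)SC(=S)N(C)C)CC1`: compound 1 gives > 5000000 nM, a limit of the assay.
compound 2, `CCCCSC(=S)N1CCN(C(=S)SC(=S)N(C)C)CC1`: compound 2 gives > 5000000 nM, likewise a limit of the assay.

Compound 2 thus stands only at a limit in this assay, with no number of its own. Going by the values given here, the single measured step at this position, the step from compound 1 to compound 2, is a step that the two limits leave unreadable from compound 1 to compound 2, because the limit of > 5000000 nM in this assay, at which 2 of the 2 values shown sit, covers both values.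

Compound 3, `CN(C)C(=S)SC(=S)N1CCN(C(=S)SCc2ccccc2)CC1`, differs from compound 2 by phenyl in place of propyl on a saturated chain carbon bound to a sulfur. Among the compounds with values here, no measured step bearing on this change has a readable size, so no shift beyond the scatter can be foreseen; the expected step is a number no higher from compound 2 to compound 3 (the limit leaves the size open), meaning compound 3 is expected to sit at the same limit. The estimate for compound 3 in this assay is 5000000 nM, with a range from 1000000 nM to 20000000 nM.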

Compound 3, half-maximal inhibitory concentration: > 5000000 nM
Compound 3: a limit, no number (the forecaster's own chance of this, stated with the estimate: 85%); the middle value sits exactly at the limit.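

No step among compound 1, compound 2 and compound 3 can be read in this assay, because all three meet the same boundary: the limit of > 5000000 nM in this assay, at which 3 of the 3 values shown sit.

The compounds shown leave open whether the groups on the saturated chain carbon bound to a sulfur differ at all in this read-out.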